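Pentafluorosulfanyl-bearing anilides and thiohydantoins: antiproliferative notes

This account rests on a few compounds, and the source may have more. Where it says the series, first, only, none or still open, it means among the compounds named here.

Measured compounds:
compound 1 `CC(O)(CSc1ccc(S(F)(F)(F)(F)F)cc1)C(=O)Nc1ccc(C#N)cc1C(F)(F)F` — 17700 nM
compound 2 `CC(O)(CSc1ccc(S(F)(F)(F)(F)F)cc1)C(=O)Nc1ccc([N+](=O)[O-])cc1C(F)(F)F` — 14500 nM
compound 3 `CC1(C)C(=O)N(c2ccc([N+](=O)[O-])c(C(F)(F)F)c2)C(=S)N1c1cccc(S(F)(F)(F)(F)F)c1` — 100000 nM

In a functional assay on DU-145 cells (Homo sapiens) for antiproliferative activity, read by propidium iodide staining, with a stated time of 96 h (on this read-out lower numbers stand for stronger inhibition and higher numbers for weaker inhibition), compound 2 gives 14500 nM and compound 1 gives 17700 nM; the change cyano in place of nitro on an aromatic carbon gave a 1.2-fold higher number from compound 2 to compound 1 (0.09 log units; within the scatter). Compound 3 gives 100000 nM, the highest number of the three; how its core differs from that of compound 2 is not broken down here.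

Compound 4 `CC1(C)C(=O)N(c2ccc(C#N)c(C(F)(F)F)c2)C(=S)N1c1cccc(S(F)(F)(F)(F)F)c1` is unmeasured. It differs from compound 3 by cyano in place of nitro on an aromatic carbon. This is the same kind of change as between compound 2 and compound 1, but the surroundings differ: in compound 4 the cyano is ortho to a trifluoromethyl group, in compound 1 meta to it. Going by the values given here, with only one earlier step to go on, the expected step from compound 3 to compound 4 in this assay is no change at the digits printed from compound 3 to compound 4 (within the scatter), resting on a 1.2-fold higher number from compound 2 to compound 1 (0.09 log units; within the scatter) being within the scatter. Compound 4 is therefore estimated at 100000 nM, between 40000 nM and 250000 nM.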

Compound 4, half-maximal inhibitory concentration: 100000 nM
Compound 4: middle estimate and measured number agree at the digits printed, within the range that was stated.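

In this assay, cyano in place of nitro on an aromatic carbon gives no change at the digits printed from compound 3 to compound 4 (within the scatter). Set beside the earlier step, the change carries from one core to the other with no difference that can be told apart: the same change on two cores in this assay, a 1.2-fold higher number (0.09 log units; within the scatter) from compound 2 to compound 1 and no change at the digits printed (within the scatter) from compound 3 to compound 4, 1.2-fold (0.09 log units) apart, within the scatter of two such steps. This holds only for these two cores in this one assay; it does not show that the change would stay as small on a third core or in another cell line, and it gives no reason for the result.

On these data alone, whether another group on this aromatic carbon, such as an amine or a carboxylic acid, would give similar numbers remains open. Also open, as far as these compounds go, is whether a longer chain in place of a methyl group on the core of compound 3 would shift its number.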